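From dimethylamino to ethyl on the shared core

This account rests on a few compounds, and the source may have more. Where it says the series, first, only, none or still open, it means among the compounds named here.

In a functional assay on HaCaT cells (Homo sapiens) for antiproliferative activity, read by sulforhodamine B assay, with a stated time of 3 days (a higher number here means a weaker inhibitor, a lower number a stronger inhibitor), compound 3 `COC(=O)c1cc(CCc2cc(OC)ccc2N(C)C)ccc1O` gives 650 nM. Compound 1 `COC(=O)c1cc(CCc2cc(OC)ccc2O)ccc1O` gives 1100 nM, and the measured step is a 1.7-fold lower number from compound 1 to compound 3 (0.23 log units; within the scatter), so these two cannot be told apart. Compound 2 `CCOc1ccc(OC)cc1CCc1ccc(O)c(C(=O)OC)c1` gives 120 nM, and the step to the dimethylamino compound is a 5.4-fold higher number from compound 2 to compound 3 (0.73 log units; beyond the scatter).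

Compound 4 `CCc1ccc(OC)cc1CCc1ccc(O)c(C(=O)OC)c1` has ethyl in place of dimethylamino on an aromatic carbon, ortho to a large group and para to a methoxy group: ethyl in place of dimethylamino on an aromatic carbon. For the measured compounds named here, no measured compound carries ethyl directly on that carbon, so the evidence is indirect. The closest guide is compound 2, whose ethoxy stands on the same carbon. The step of a 9.2-fold lower number from compound 1 to compound 2 (0.96 log units; beyond the scatter) also shows a lower number with ethoxy than with hydroxy. A move to a lower number is therefore expected, somewhat smaller than the gap between compound 2 and compound 3, though still beyond the scatter. For compound 4 the expected step is a 3.3-fold lower number from compound 3 to compound 4 (0.51 log units; beyond the scatter). Compound 4 is estimated at 200 nM, with an expected range of 70 nM to 550 nM.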

Compound 4, half-maximal inhibitory concentration: 130 nM
Compound 4: the middle estimate sits 1.5-fold (0.19 log units) above what was measured; low and high end bracket the measured number.
By their numbers in this assay, from the lowest: compounds 2 and 4 (each within the scatter of the next); then compounds 3 and 1 (each within the scatter of the next).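

In this assay, the aromatic carbon ortho to a large group and para to a methoxy group now has a measured step to ethyl, a 5.0-fold lower number from compound 3 to compound 4 (0.70 log units; beyond the scatter) and likewise an 8.5-fold lower number from compound 1 to compound 4 (0.93 log units; beyond the scatter) from the hydroxy compound. The ethoxy comparison gives a 1.1-fold higher number from compound 2 to compound 4 (0.03 log units; within the scatter) and so ethyl and ethoxy cannot be told apart, which shows that an oxygen attached to this carbon is not required for the low number seen with compound 2. No measurement shown explains what separates these two groups from dimethylamino and hydroxy at this position.

Going by these compounds, whether the low number extends to a methyl group or a longer chain such as propyl on this carbon stays open. So does whether a primary amine would stand with dimethylamino or with ethyl.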